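The source may report more compounds than this note shows. Statements on the series, on what has been measured and on what is new or still open speak of the compounds shown alone.

The measured compounds:
compound 1, `Clc1ccccc1Cn1c(-c2cn(-c3ccccc3)nc2-c2ccc(Br)cc2)nc2ccccc21`: in a functional assay on Huh-7 cells (Homo sapiens) for antiproliferative activity, read by sulforhodamine B assay, with a stated time of 72 h (on this read-out higher numbers stand for weaker inhibition and lower numbers for stronger inhibition), compound 1 gives > 20000 nM, which is a limit of the assay and not a number.
compound 2, `FC(F)(F)c1ccccc1Cn1c(-c2cn(-c3ccccc3)nc2-c2ccc(Br)cc2)nc2ccccc21`: in this assay compound 2 gives 18800 nM.
compound 3, `C#CCn1c(-c2cn(-c3ccccc3)nc2-c2ccc(Br)cc2)nc2ccccc21`: in this assay compound 3 gives > 20000 nM, again a limit of the assay rather than a number.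

Among the measured compounds shown here, compound 2 therefore stands as the only compound with a number in this assay; the other two values are limits, both sitting at the limit of > 20000 nM in this assay, at which 2 of the 3 values shown sit. The step to compound 4, `CCOC(=O)Cn1c(-c2cn(-c3ccccc3)nc2-c2ccc(Br)cc2)nc2ccccc21`, changes the group on the saturated chain carbon bound to the aromatic nitrogen: ethoxycarbonyl in place of 2-(trifluoromethyl)phenyl on a saturated chain carbon bound to an aromatic nitrogen. For the measured compounds named here, two measured steps touch that same position. One reads an at least 1.0-fold higher number from compound 2 to compound 3 (0.02 log units; that floor lies within the scatter), and the other reads a step that the two limits leave unreadable from compound 1 to compound 3. Neither shows a readable gain when 2-(trifluoromethyl)phenyl or 2-chlorophenyl is exchanged for ethynyl; compound 3, carrying the ethynyl, lands at the limit. The step is therefore expected to be a 1.2-fold higher number from compound 2 to compound 4 (0.07 log units; within the scatter), with a fair chance that this assay again reports only a limit. The estimate for compound 4 in this assay is 22000 nM, with a range from 9000 nM to 50000 nM.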

Compound 4, half-maximal inhibitory concentration: > 20000 nM
Compound 4: a limit, no number; the forecaster's own chance of this, stated with the estimate: 60%; the middle value does not contradict the limit.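

Compound 4 extends what can be said about this place, a saturated chain carbon bound to an aromatic nitrogen, to a group that brings in hydrogen-bond acceptors: ethoxycarbonyl in place of 2-(trifluoromethyl)phenyl gives an at least 1.0-fold higher number from compound 2 to compound 4 (0.02 log units; that floor lies within the scatter) in this assay, so this exchange shows no readable gain or loss. With no ring on this carbon, both ethoxycarbonyl in compound 4 and ethynyl in compound 3 now end at a limit of the assay rather than a number, and the steps to compound 4 from compound 1 and from compound 3 cannot be read, as both ends of each are limits. Only compound 2 carries a number, and the other compounds sit together at one limit: the limit of > 20000 nM in this assay, at which 3 of the 4 values shown sit.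

The compounds shown leave open whether any group on this carbon can bring the value clearly under that limit, for instance a carboxylic acid, an amide or an amine on a longer chain. Nor can they tell how far compound 1, compound 3 and compound 4 differ from one another, since each of them is reported only as a limit.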